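Replacing the (naphthalen-2-yl)oxy group of compound 2

A few compounds are considered here, and "the series" means these few. Any claim that something is new, unique, unknown or untested is made for them only; others in the source may bear on it.

- Compound 1 `Fc1ccc(C(c2ccc(F)cc2)C2CCN(CCCOc3ccc(Br)cc3)CC2)cc1`: 1.59 nM
- Compound 2 `Fc1ccc(C(c2ccc(F)cc2)C2CCN(CCCOc3ccc4ccccc4c3)CC2)cc1`: 7.94 nM
- Compound 3 `CN(CCCN1CCC(C(c2ccc(F)cc2)c2ccc(F)cc2)CC1)c1ccccc1`: not yet measured

In a functional assay (aorta) with Oryctolagus cuniculus as the target (on this read-out lower numbers stand for tighter binding and higher numbers for weaker binding), compound 2 has the higher of the two numbers, which means weaker binding. Compound 3 has methyl(phenyl)amino in place of (naphthalen-2-yl)oxy on a saturated chain carbon, three bonds along the chain from an amine nitrogen in a ring. Among the compounds with values here, the only measured step, a 5.0-fold higher number from compound 1 to compound 2 (0.70 log units; beyond the scatter), was modest and also changed the group at this end of the chain. It gives size but no sure direction here, so a step no larger than that one is expected in this assay. The estimated step is a 1.3-fold lower number from compound 2 to compound 3 (0.12 log units; within the scatter). For compound 3 the expected value is 6 nM, with an estimated range from 1.5 nM to 25 nM.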

Compound 3, dissociation constant: 2 nM
Beside the measured number, compound 3's estimate is 3.0-fold (0.48 log units) above it; the measured number falls inside the stated range.
By their numbers in this assay, from the lowest: compounds 1 and 3 (each within the scatter of the next); then compound 2.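

In this assay the swap gives a 4.0-fold lower number from compound 2 to compound 3 (0.60 log units; beyond the scatter) and shows that this end of the chain does not need an oxygen link. Set against 4-bromophenoxy, methyl(phenyl)amino gives a 1.3-fold higher number from compound 1 to compound 3 (0.10 log units; within the scatter) so these two end groups, each with one aromatic ring, read alike, while compound 2, with two aromatic rings, stands apart. Nothing available explains this difference. Still open, on these data alone, is whether phenylamino, without the methyl, would read the same, and whether a longer chain would keep this level.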